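The source may hold more compounds than are shown below. What is called first, only, known or untested is meant among the compounds shown, and "the series" means these compounds.

In an ADME assay on S9 fraction from liver (Homo sapiens) for metabolic stability, read by LC-MS, using NADPH, with stated times of 5 min and 60 min, tested at 5 uM (a lower number here means that less of the compound is left, a higher number that more of the compound is left), compound 1 (`COc1cc(C2CN(C(=O)c3cc(OCCO)ccn3)C2)ccc1OCc1ccc(C2CC2)cc1`) gives 47% and compound 2 (`COc1ccc(COc2ccc(C3CN(C(=O)c4cc(OCCO)ccn4)C3)cc2OC)cc1`) gives 38% so the two stand level within the scatter. Compound 3 (`COc1cc(C2CN(C(=O)c3cc(OC[C@H](O)CO)ccn3)C2)ccc1OCc1ccc(C2CC2)cc1`) differs from compound 1 in one place, where 2-hydroxyethoxy becomes 2,3-dihydroxypropoxy (hydroxymethyl in place of hydrogen on a saturated chain carbon bound to an oxygen on a saturated carbon and a saturated chain carbon). Among the measured compounds shown here, the one measured step (a number 9 percentage points lower from compound 1 to compound 2 (within the scatter)) lies within the scatter and concerns methoxy in place of cyclopropyl rather than this chain, so it offers only a weak guide. No step beyond the scatter is therefore expected in this assay and the estimated step (a number 1 percentage points higher from compound 1 to compound 3 (within the scatter)) stays within it. Compound 3 is expected at 48% within a range of 32% to 65% as estimated.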

Compound 3, percent of the compound remaining: 64%
Estimate against measurement, compound 3: 16 percentage points below; the measured number falls inside the stated range.
By their numbers in this assay, from the lowest: compounds 2 and 1 (each within the scatter of the next); then compound 3.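

In this assay, the change from 2-hydroxyethoxy to 2,3-dihydroxypropoxy gives a number 17 percentage points higher from compound 1 to compound 3 (beyond the scatter), the only step beyond the scatter among these compounds. It shows that hydroxymethyl in place of hydrogen on this saturated chain carbon can shift the percent of compound remaining, which the cyclopropyl-to-methoxy step did not show. Nothing available explains this gain. Going by these compounds, whether the same change would carry over to compound 2 remains open. So does how an amine, a carboxylic acid or a longer chain at this carbon would compare with hydroxymethyl.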